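Fluorine placement on a diaryl thiazole acetic acid antagonist

The compounds below may be only part of what the source reports. "The series", "measured", "known", "first", "only" and "open" are said of these compounds alone.

Three compounds sharing a core have been characterized in an in vitro functional assay on HEK285-7 cells for antagonist activity at prostaglandin D2 receptor 2 (Homo sapiens), read by BRET and beta-arrestin recruitment; a higher number here means a larger maximal response, a lower number a smaller maximal response. Compound 1 `O=C(O)Cc1sc(C(c2ccc(F)cc2)c2ccc(F)cc2)nc1-c1ccc(Cl)cc1` gives 80%, compound 2 `O=C(O)Cc1sc(C(c2ccccc2)c2ccc(F)cc2)nc1-c1ccc(Cl)cc1` gives 80%, and compound 3 `O=C(O)Cc1sc(C(c2ccccc2)c2ccccc2)nc1-c1ccccc1` gives 80%. The step of no change at the digits printed from compound 2 to compound 1 (within the scatter) rests on the change (fluoro in place of hydrogen on an aromatic carbon). The difference between the cores of compound 3 and compound 2 is not broken down here. Compound 4 `O=C(O)Cc1sc(C(c2ccccc2)c2ccccc2)nc1-c1cccc(F)c1` differs from compound 3 by fluoro in place of hydrogen on an aromatic carbon; this is the same kind of change as that from compound 2 to compound 1, though the place differs, being meta to a large group rather than para to a large group. Because compound 1 and compound 2 share no change at the digits printed from compound 2 to compound 1 (within the scatter), compound 4 is expected to show no change at the digits printed from compound 3 to compound 4 (within the scatter). Compound 4 is thus estimated at 80%, between 70% and 90%.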

Compound 4, largest response reached (reported as efficacy), in percent of the reference or control that the assay uses: 80%
The estimate for compound 4 equals the measured number at the digits printed, and the stated range covers the measured number.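

In this assay, fluoro in place of hydrogen on an aromatic carbon gives no change at the digits printed from compound 3 to compound 4 (within the scatter), and this matches the earlier step on another core: the same change on two cores in this assay, no change at the digits printed (within the scatter) from compound 2 to compound 1 and no change at the digits printed (within the scatter) from compound 3 to compound 4, 0 percentage points apart, within the scatter of two such steps

Across these two cores, then, the change carries over as a step that stays within the scatter, even though it sits at a different place in each. This does not show that the same would hold on other cores or at other places on the ring, and two such steps are too few to establish a rule for the series.

The compounds shown leave open how a larger replacement on that ring, such as methoxy or an amine, would read. They also leave open what an amide in place of the carboxylic acid would do.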